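Ethylamino in place of methylamino on the bicyclic nucleoside core

This account rests on a few compounds, and the source may have more. Where it says the series, first, only, none or still open, it means among the compounds named here.

Two compounds of the series have numbers in an assay on HEK293 cells for displacement of a labelled ligand from adenosine receptor A3 (Mus musculus), read by scintillation counting, with a stated time of 60 min; on this read-out higher numbers stand for weaker inhibition and lower numbers for stronger inhibition. Compound 1 `CNC(=O)[C@@]12C[C@@H]1[C@@H](n1cnc3c(NCc4cccc(Cl)c4)nc(C#Cc4cccc(S(=O)(=O)O)c4)nc31)[C@H](O)[C@@H]2O` gives 11.3 nM there. Compound 2 `CNc1nc(C#Cc2ccccc2)nc2c1ncn2[C@H]1[C@H](O)[C@H](O)[C@@H]2C[C@@H]21` gives 1530 nM in this assay, the higher of the two numbers by a gap well beyond the scatter, so compound 2 stands as the weaker of the measured pair. The next step keeps everything of compound 2 except one change: methyl in place of hydrogen on a saturated chain carbon bound to a nitrogen on an aromatic ring, that is methyl to ethyl, methylamino to ethylamino, giving compound 3 `CCNc1nc(C#Cc2ccccc2)nc2c1ncn2[C@H]1[C@H](O)[C@H](O)[C@@H]2C[C@@H]21`. Going by the values given here, no measured step of this kind exists, so the expectation rests on compound 2 alone. The change is small, and the step from compound 2 to compound 3 in this assay is expected to be a 1.0-fold lower number from compound 2 to compound 3 (0.01 log units; within the scatter), within the scatter in either direction. Compound 3 is therefore estimated at 1500 nM in this assay, in a range from 500 nM to 4500 nM.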

Compound 3, inhibition constant: 1480 nM
For compound 3 the middle estimate is 1.0-fold (0.01 log units) above the measured one, within the range that was stated.
By their numbers in this assay, from the lowest: compound 1; then compounds 3 and 2 (each within the scatter of the next).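

Going from methylamino to ethylamino gives a 1.0-fold lower number from compound 2 to compound 3 (0.01 log units; within the scatter) in this assay, so one added methyl on a saturated chain carbon bound to a nitrogen on an aromatic ring leaves the number within the scatter. Going by these compounds alone, this is the first one-place pair, and it gives the first direct reading of a change at this position, which the two earlier compounds could not give. No measured property of these compounds bears on this result.

On these data alone, whether the number stays put with a longer or bulkier group at this position, such as propylamino, isopropylamino or cyclopropylamino, remains open. Also open, as far as these compounds go, is whether methyl to ethyl reads the same on a different core, such as the core of compound 1.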